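Chloro substituent on the core-attached phenyl of compound 1

This account rests on a few compounds, and the source may have more. Where it says the series, first, only, none or still open, it means among the compounds named here.

Compound 1 `Cn1c(N2N=C(c3ccccc3)CC2c2ccccc2)nc(-c2ccccc2)c(C#N)c1=O` gives 35400 nM in a functional assay on MCF7 cells (Homo sapiens) for antiproliferative activity, with a stated time of 72 h (a lower number here means a stronger inhibitor, a higher number a weaker inhibitor), the second highest of the three numbers in hand; compound 3 `Cn1c(N2N=C(c3ccccc3)CC2c2ccc(F)cc2)nc(-c2ccccc2)c(C#N)c1=O` gives 38100 nM and compound 2 `COc1ccc(C2CC(c3ccccc3)=NN2c2nc(-c3ccccc3)c(C#N)c(=O)n2C)cc1` gives 18000 nM. Compound 4 `Cn1c(N2N=C(c3ccccc3)CC2c2ccccc2)nc(-c2ccc(Cl)cc2)c(C#N)c1=O` differs from compound 1 by chloro in place of hydrogen on an aromatic carbon. Among the compounds with values here, no measured step alters this ring; the steps of a 2.0-fold lower number from compound 1 to compound 2 (0.29 log units; within the scatter) and a 1.1-fold higher number from compound 1 to compound 3 (0.03 log units; within the scatter) concern the phenyl on the pyrazoline and stay within the scatter, while a 2.1-fold higher number from compound 2 to compound 3 (0.33 log units; beyond the scatter) is modest. Substituents on an aromatic ring of this series have so far moved the number little, so for compound 4 the expected step in this assay is estimated as a 1.2-fold lower number from compound 1 to compound 4 (0.07 log units; within the scatter), not beyond the scatter. Compound 4 is estimated at 30000 nM, within 12000 nM to 80000 nM.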

Compound 4, half-maximal inhibitory concentration: 34400 nM
Compound 4: the middle estimate sits 1.1-fold (0.06 log units) below what was measured, and the stated range covers the measured number.
By their numbers in this assay, from the lowest: compounds 2, 4, 1 and 3 (each within the scatter of the next, the first and the last beyond it).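

Phenyl to 4-chlorophenyl on the core-attached ring gives a 1.0-fold lower number from compound 1 to compound 4 (0.01 log units; within the scatter) in this assay. This extends the picture beyond the other phenyl: a halogen on this ring, para to a large group, also leaves the number within the scatter. No supporting data bear on why this change is so flat.

Open, from the compounds shown here alone, is whether methoxy at this place, or an amine or a carboxylic acid, would move the number beyond the scatter. Also open, going by these compounds, is whether any substituent on this ring could bring the series well below the values in hand.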